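Swapping aminomethyl for dimethylcarbamoyl: cytotoxicity outlook

The compounds below may be only part of what the source reports. "The series", "measured", "known", "first", "only" and "open" are said of these compounds alone.

Compound 1 `CC(C)CCn1c(Cn2c(=O)n(C(C)C)c3ccccc32)nc2cc(CN)ccc21` gives 3920 nM
Compound 2 `CC(C)CCn1c(Cn2c(=O)n(C)c3ccccc32)nc2cc(-c3nnn(C)n3)ccc21` gives 2970 nM

Both compounds were tested in an ADME assay on HEp-2 cells (Homo sapiens) for cytotoxicity; on this read-out lower numbers stand for higher toxicity in this test and higher numbers for lower toxicity in this test. Going by the values given here, compound 1 and compound 2 give numbers that lie within the usual scatter of each other, so the two cannot be told apart on this read-out, and no firm step stands between them. Compound 3 `CC(C)CCn1c(Cn2c(=O)n(C(C)C)c3ccccc32)nc2cc(C(=O)N(C)C)ccc21` has not yet been measured in this assay. It differs from compound 1 in one place: dimethylcarbamoyl in place of aminomethyl on an aromatic carbon. Compound 2 shows that a quite different group at the same kind of position, alongside a change elsewhere on the core, leaves the number close to that of compound 1, so a small step is expected here, a 1.0-fold higher number from compound 1 to compound 3 (0.01 log units; within the scatter), with no clear direction beyond the scatter. Compound 3 is therefore estimated at 4000 nM, within a range from 1500 nM to 11000 nM.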

Compound 3, half-maximal cytotoxic concentration: 25600 nM
For compound 3 the middle estimate is 6.4-fold (0.81 log units) below the measured one; the whole stated range lies below it.
By their numbers in this assay, from the lowest: compounds 2 and 1 (each within the scatter of the next); then compound 3.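

In this assay the group on this aromatic carbon turns out to matter: dimethylcarbamoyl in place of aminomethyl gives a 6.5-fold higher number from compound 1 to compound 3 (0.81 log units; beyond the scatter) and so moves toward lower toxicity in this test. This is the first pair shown that differs in this one place alone, so the shift belongs to this swap, which takes away the hydrogen-bond donor of aminomethyl and brings in a carbonyl. Nothing shown explains why the number moves.

The compounds shown leave open which part of the swap carries the step: a primary amide or a dimethylaminomethyl group on the same aromatic carbon would help separate the carbonyl from the two methyl groups. As far as these compounds go, whether the swap gives a similar step when the isopropyl group on the core is replaced by methyl also remains open.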